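This account rests on a few compounds, and the source may have more. Where it says the series, first, only, none or still open, it means among the compounds named here.

Compound 1, `O=C(Nc1cccc(-n2cc(-c3ccncc3)c(-c3ccc(Cl)c(O)c3)n2)c1)Nc1ccc(Cl)c(Cl)c1`: 22700 nM
Compound 2, `COc1cc(-c2nn(-c3cccc(NC(=O)c4ccc(Cl)c(C(F)(F)F)c4)c3)cc2-c2ccncc2)ccc1Cl`: > 32500 nM
Compound 3, `O=C(Nc1cccc(-n2cc(-c3ccncc3)c(-c3ccc(Cl)c(O)c3)n2)c1)Nc1cc(C(F)(F)F)cc(C(F)(F)F)c1`: 2920 nM

In a functional assay on COLO 205 cells (Homo sapiens) for inhibition, read by sulforhodamine B assay, with a stated time of 48 h (on this read-out higher numbers stand for lower toxicity in this test and lower numbers for higher toxicity in this test), compound 2 reaches only a limit, (the limit of > 32500 nM in this assay, at which 1 of the 3 values shown sits), so no number stands for it. Compound 4, `COc1cc(-c2nn(-c3cccc(NC(=O)Nc4cccc(C(F)(F)F)c4)c3)cc2-c2ccncc2)ccc1Cl`, has not yet been measured in this assay. It differs from compound 2 by (3-(trifluoromethyl)phenyl)amino in place of 4-chloro-3-(trifluoromethyl)phenyl on a carbonyl carbon, so a urea takes the place of the amide. Compound 1 and compound 3, both ureas, give numbers rather than limits in this assay, and compound 3 gives the lower of the two. On that basis a step toward lower numbers, of moderate size, is expected from compound 2 to compound 4, an at least 2.1-fold lower number from compound 2 to compound 4 (0.33 log units; beyond the scatter). Compound 4 is therefore estimated at 15000 nM in this assay, within 4000 nM to 40000 nM.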

Compound 4, concentration lethal to 50% of the cells: 3430 nM
Estimate against measurement, compound 4: 4.4-fold (0.64 log units) above; measured number outside the range, below it.
By their numbers in this assay, from the lowest: compounds 3 and 4 (each within the scatter of the next); then compound 1. At a limit, above all of these: compound 2.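

In this assay, (3-(trifluoromethyl)phenyl)amino in place of 4-chloro-3-(trifluoromethyl)phenyl on a carbonyl carbon brings an at least 9.4-fold lower number from compound 2 to compound 4 (0.97 log units; beyond the scatter). This is the first direct comparison at this position, since no pair shown before differed in one place, and it shows that the number here responds strongly to this change. Compound 2 stands at a limit, so the full size of the step cannot be read: the limit of > 32500 nM in this assay, at which 1 of the 4 values shown sits.

The change swaps the amide for a urea and removes the chlorine together, so the compounds shown do not separate these two parts. From the compounds shown here alone, how a benzylamino or cyclohexylamino group on the same carbonyl carbon would read also remains open.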